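Compound 4: a 2-methylphenyl analogue of compound 1

The source may hold more compounds than are shown below. What is called first, only, known or untested is meant among the compounds shown, and "the series" means these compounds.

Compound 1 `CCOc1ccc(NC(=O)Nc2cccc(CNc3nccnc3Cl)c2)cc1` serves as the starting point. In a functional assay on MGC-803 cells (Homo sapiens) for antiproliferative activity, read by MTT assay, with a stated time of 48 h (a higher number here means a weaker inhibitor, a lower number a stronger inhibitor), compound 1 gives 7240 nM, the second highest of the three numbers measured. Compound 2 `Cc1ccc(NC(=O)Nc2cccc(CNc3nccnc3Cl)c2)c(C)c1` gives 10100 nM, and compound 3 `O=C(Nc1cccc(CNc2nccnc2Cl)c1)Nc1ccc(Cl)c(Cl)c1` gives 4970 nM. The step of a 1.4-fold higher number from compound 1 to compound 2 (0.14 log units; within the scatter) and the step of a 1.5-fold lower number from compound 1 to compound 3 (0.16 log units; within the scatter) both stay within the scatter, while the step of a 2.0-fold lower number from compound 2 to compound 3 (0.31 log units; beyond the scatter) is modest.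

Compound 4 `Cc1ccccc1NC(=O)Nc1cccc(CNc2nccnc2Cl)c1` differs from compound 1 by 2-methylphenyl in place of 4-ethoxyphenyl on an amide-type nitrogen. The measured step that bears most directly on this change is a 1.4-fold higher number from compound 1 to compound 2 (0.14 log units; within the scatter), where the entering group was 2,4-dimethylphenyl on the same amide-type nitrogen; that exchange did not move the number beyond the scatter. Going by the values given here, no measured pair separates 2-methylphenyl from 2,4-dimethylphenyl, so the expectation for compound 4 is a number close to that of compound 1, with an expected step of a 1.2-fold higher number from compound 1 to compound 4 (0.09 log units; within the scatter). Compound 4 is therefore estimated at 9000 nM, with a range from 4500 nM to 18000 nM.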

Compound 4, half-maximal inhibitory concentration: 14000 nM
Compound 4: the middle estimate sits 1.6-fold (0.19 log units) below what was measured, within the range that was stated.
By their numbers in this assay, from the lowest: compounds 3, 1, 2 and 4 (each within the scatter of the next, the first and the last beyond it).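

On the amide-type nitrogen, 2-methylphenyl in place of 4-ethoxyphenyl gives a 1.9-fold higher number from compound 1 to compound 4 (0.29 log units; within the scatter) in this assay and so does not separate the two groups, although the entering group has fewer heavy atoms and no hydrogen-bond acceptor. Hydrogen in place of methyl on an aromatic carbon gives a 1.4-fold higher number from compound 2 to compound 4 (0.14 log units; within the scatter) and is the first measured single-methyl change in this set, which also leaves the two compounds unseparated. Only 2-methylphenyl in place of 3,4-dichlorophenyl gives a modest change, with a 2.8-fold higher number from compound 3 to compound 4 (0.45 log units; beyond the scatter) on the same nitrogen.

Nothing shown here accounts for these differences. The compounds shown leave open whether an amine or a carboxylic acid on this phenyl ring, or a butoxy chain in place of the ethoxy group, would move the number beyond the scatter.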